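The source may hold more compounds than are shown below. What is called first, only, known or untested is meant among the compounds shown, and "the series" means these compounds.

Measured in a functional assay on SW-620 cells (Homo sapiens) for cytotoxicity, read by MTT assay, with a stated time of 3 days; on this read-out higher numbers stand for an effect only at larger amounts of compound and lower numbers for an effect already at smaller amounts:

Compound 1 `O=C1/C(=C/c2c(Cl)cccc2Cl)c2ccccc2N1c1c(Cl)cccc1Cl`: > 100 ug/mL (a limit)
Compound 2 `O=C1C(/C=C\c2cccc(Br)c2)c2ccccc2N1c1c(Cl)cccc1Cl`: 50 ug/mL
Compound 3 `O=C1/C(=C/c2cccc(Oc3ccccc3)c2)c2ccccc2N1c1c(Cl)cccc1Cl`: 50 ug/mL

Compound 1 has no numerical value, only a limit of > 100 ug/mL. Within the data shown here, it is the only one of the three compounds in this position, whereas compound 2 and compound 3 both gave numbers.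

The next compound to be tested is compound 4 `CN(C)c1ccc(/C=C2/C(=O)N(c3c(Cl)cccc3Cl)c3ccccc32)cc1`. It carries 4-(dimethylamino)phenyl in place of 2,6-dichlorophenyl on a double-bonded chain carbon bound to a double-bonded ring carbon.

Among the measured compounds shown here, no measured pair isolates this kind of change, so any expectation is tentative. Compound 2 gave 50 ug/mL and compound 3 gave 50 ug/mL, and neither has 2,6-dichlorophenyl on the chain. On that basis, a modest move toward a lower number in this assay is expected, with a reading at the limit still possible. The estimated change is an at least 2.5-fold lower number from compound 1 to compound 4 (0.39 log units; beyond the scatter). For compound 4 the expected value is 40 ug/mL, with an estimated range of 15 ug/mL to 100 ug/mL.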

Compound 4, concentration for half-maximal effect: > 100 ug/mL
Compound 4 ended at the assay's limit; the forecaster's own chance of this, stated with the estimate: 25%; middle value at least 2.5-fold (0.39 log units) away from the limit.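

Among these compounds, compound 1 and compound 4 both ended at a limit rather than a number, so no step between them can be read: the limit of > 100 ug/mL in this assay, at which 2 of the 4 values shown sit.

The compounds shown leave open whether 4-(dimethylamino)phenyl in place of 2,6-dichlorophenyl changes cytotoxicity at all.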